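Aryl replacement on the shared core: forecast for compound 3

The compounds below may be only part of what the source reports. "The series", "measured", "known", "first", "only" and "open" are said of these compounds alone.

Measured so far in an assay on HEK-293T cells for displacement of a labelled ligand from corticotropin-releasing factor receptor 1 (Homo sapiens), read by scintillation counting, with a stated time of 2 h; a lower number here means a stronger inhibitor, a higher number a weaker inhibitor:
compound 1 `CCCCN(CC)c1cc(C)nc2c1NC(=O)CN2c1ccc(C)cc1Br`: 4.4 nM
compound 2 `CCCCN(CC)c1cc(C)nc2c1NC(=O)CN2c1ccc(OC)cc1C`: 4 nM

Among the measured compounds shown here, compound 2 gives the lowest of the two numbers in this assay, but the only measured step, a 1.1-fold lower number from compound 1 to compound 2 (0.04 log units; within the scatter), is within the scatter, so the two compounds cannot be placed in any order on this evidence.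

Compound 3 `CCCCN(CC)c1cc(C)nc2c1NC(=O)CN2c1ccc(Cl)cc1Cl` differs from compound 2 in one place: 2,4-dichlorophenyl in place of 4-methoxy-2-methylphenyl on a nitrogen on an aromatic ring in a ring.

For the measured compounds named here, the one step that bears on this change is a 1.1-fold lower number from compound 1 to compound 2 (0.04 log units; within the scatter), where the same aryl group on the ring nitrogen was exchanged and the number stayed within the scatter. The new aryl group, 2,4-dichlorophenyl, has not been measured in this series, and one step on one position gives a narrow basis for judging it. The expectation for compound 3 in this assay is therefore a number close to that of compound 2, with the step of a 1.3-fold higher number from compound 2 to compound 3 (0.10 log units; within the scatter) expected to stay within or near the scatter. Compound 3 is estimated at 5 nM, with a range from 1.5 nM to 16 nM.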

Compound 3, inhibition constant: 3.4 nM
Compound 3: middle estimate off by 1.5-fold (0.17 log units), on the high side; measured number inside the range.
By their numbers in this assay, from the lowest: compounds 3, 2 and 1 (each within the scatter of the next).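

On the nitrogen of the shared core, 2,4-dichlorophenyl in place of 4-methoxy-2-methylphenyl gives a 1.2-fold lower number from compound 2 to compound 3 (0.07 log units; within the scatter) in this assay and, in place of 2-bromo-4-methylphenyl, gives a 1.3-fold lower number from compound 1 to compound 3 (0.11 log units; within the scatter) so all three aryl groups shown at this position lie within the scatter of one another. The earlier step exchanged one carbon-and-bromine-bearing aryl group for a methoxy-bearing one, whereas this pair sets an aryl group with two chlorine atoms and no hydrogen-bond acceptor against one with an oxygen and one hydrogen-bond acceptor, and this assay still does not separate the compounds. No measurement offered here accounts for this lack of separation.

Going by these compounds, whether this tolerance extends to other groups on the nitrogen remains open, since a plain unsubstituted phenyl, a phenyl carrying a carboxylic acid or an amine, or a saturated cyclohexyl ring could yet give a step beyond the scatter. All three compounds also share the butyl and ethyl groups on the amine of the core, so a longer chain or a cyclopropylmethyl group there has no reading from these numbers.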